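Aryl substituent swap on the ether side chain

The source may hold more compounds than are shown below. What is called first, only, known or untested is meant among the compounds shown, and "the series" means these compounds.

Going by the values given here, compound 1 `Cc1cc(C(=O)O)ccc1CN1CCC[C@H](O[C@H](CO)c2cc(F)cc(F)c2)[C@@H]1c1ccccc1` carries the lowest number of the three measured so far: in an assay on isolated protein for activation of cGMP-dependent protein kinase 1 (Homo sapiens), read by ADP-Glo, with stated times of 30 min and 2 h, in the presence of a further agent that is not named here (on this read-out lower numbers stand for an effect already at smaller amounts and higher numbers for an effect only at larger amounts of compound), compound 1 gives 1500 nM. Compound 2 `Cc1cc(C(=O)O)ccc1CN1CCC[C@H](O[C@H](CF)c2cc(Cl)cc(Cl)c2)[C@@H]1c1ccccc1` gives 9100 nM, and compound 3 `Cc1cc(C(=O)O)ccc1CN1CCC[C@H](OC(c2cc(Cl)cc(Cl)c2)C(C)O)[C@@H]1c1ccccc1` gives 5300 nM. The steps of a 6.1-fold higher number from compound 1 to compound 2 (0.78 log units; beyond the scatter) and a 3.5-fold higher number from compound 1 to compound 3 (0.55 log units; beyond the scatter) each exchange the whole side group on the ether oxygen, ring halogens and chain together, so neither isolates a change on the ring alone; between compound 2 and compound 3 the step of a 1.7-fold lower number from compound 2 to compound 3 (0.23 log units; within the scatter) is small. Compound 4 `Cc1cc(C(=O)O)ccc1CN1CCC[C@H](O[C@H](CO)c2cccc(C(F)(F)F)c2)[C@@H]1c1ccccc1` differs from compound 1 by 3-(trifluoromethyl)phenyl in place of 3,5-difluorophenyl on a saturated chain carbon bound to an oxygen on a saturated carbon and a saturated chain carbon, with the rest of the molecule kept. Among the compounds with values here, no measured step bears directly on this change; the nearest steps were modest moves to higher numbers, so in this assay a step of similar or smaller size, if any, is expected. Compound 4 is expected at 2500 nM (range 800 nM to 8000 nM), a step of a 1.7-fold higher number from compound 1 to compound 4 (0.22 log units; within the scatter).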

Compound 4, half-maximal effective concentration: 4100 nM
Compound 4: the middle estimate sits 1.6-fold (0.21 log units) below what was measured; low and high end bracket the measured number.
By their numbers in this assay, from the lowest: compound 1; then compounds 4, 3 and 2 (each within the scatter of the next, the first and the last beyond it).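

Going by these compounds alone, with the rest of the molecule kept, the step of a 2.7-fold higher number from compound 1 to compound 4 (0.44 log units; beyond the scatter) in this assay is the first reading of a change on the aryl ring alone, with the chain untouched. The ring group at this place therefore moves the number by itself, and of the two groups compared here, 3,5-difluorophenyl gives the lower number. No measured data explain this step. As far as these compounds go, how a nitrile or a methoxy group on this ring would read remains open. From the compounds shown here alone, the separate contribution of the chain also remains open, since compound 2 and compound 3 change ring and chain together.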